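Swapping one long selenium chain for another on compound 1

The source may hold more compounds than are shown below. What is called first, only, known or untested is meant among the compounds shown, and "the series" means these compounds.

In a functional assay on RKO cells (Homo sapiens) for inhibition, read by MTT assay, with a stated time of 48 h (on this read-out lower numbers stand for stronger inhibition and higher numbers for weaker inhibition), compound 1 (`COc1ccc(N(C)c2nc(C)nc3ccccc23)cc1C(=O)NCC[Se]C#N`) gives 1170 nM, the second highest of the three numbers measured. Compound 3 (`COc1ccc(N(C)c2nc(C)nc3ccccc23)cc1OCCCC[Se]C#N`) gives 1360 nM, which lies within the scatter of compound 1. Compound 2 (`COc1ccc(N(C)c2nc(C)nc3ccccc23)cc1[Se]C`) gives 11 nM, far lower than both.

The unmeasured compound 4 (`COc1ccc(N(C)c2nc(C)nc3ccccc23)cc1C(=O)OCCCCC[Se]C#N`) keeps the shared core and the carbonyl of compound 1, and only the chain changes: a group of 9 heavy atoms (6 carbon, 1 nitrogen, 1 oxygen, 1 selenium; no ring) in place of a group of 6 heavy atoms (3 carbon, 2 nitrogen, 1 selenium; no ring), on a carbonyl carbon.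

Among the compounds with values here, the closest precedent is the exchange of one selenium chain ending in a nitrile for another, which gave a 1.2-fold higher number from compound 1 to compound 3 (0.07 log units; within the scatter). The large steps all involve the small group of compound 2: a 110-fold lower number from compound 1 to compound 2 (2.03 log units; beyond the scatter), and a 120-fold higher number from compound 2 to compound 3 (2.09 log units; beyond the scatter). Compound 4 has a long nitrile-bearing chain and not that small group, so those large steps bear on it only weakly. Within the data shown here, no measured compound has exactly this chain or link, which keeps the range wide.

Going by compound 3 and its a 1.2-fold higher number from compound 1 to compound 3 (0.07 log units; within the scatter), no change beyond the scatter is expected in this assay. The expected step is a 1.0-fold higher number from compound 1 to compound 4 (0.01 log units; within the scatter). Compound 4 is estimated at 1200 nM, with an expected range of 400 nM to 3500 nM.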

Compound 4, half-maximal inhibitory concentration: 356 nM
For compound 4 the middle estimate is 3.4-fold (0.53 log units) above the measured one; the whole stated range lies above it.
By their numbers in this assay, from the lowest: compound 2; then compound 4; then compounds 1 and 3 (each within the scatter of the next).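

On the carbonyl carbon of compound 1, replacing the chain gives a 3.3-fold lower number from compound 1 to compound 4 (0.52 log units; beyond the scatter) in this assay, so a chain that keeps its selenium and nitrile can still shift the number beyond the scatter. The earlier exchange of one long selenium chain for another, a 1.2-fold higher number from compound 1 to compound 3 (0.07 log units; within the scatter), did not show this, as it stayed within the scatter and could have suggested that such swaps make little difference on this core. Here the chain grows from 6 to 9 heavy atoms and the count of hydrogen-bond donors falls from 1 to 0, so two things change in a single step, and no measurement at hand explains why the number drops.

On these data alone, whether the gain comes from the added length or from the oxygen link that replaces the amide hydrogen stays open; an amide-linked chain as long as that of compound 4, or an oxygen-linked chain as short as that of compound 1, would separate the two. As far as these compounds go, it is equally open how a longer chain, or a carboxylic acid on this carbonyl carbon, would read in this assay and whether the selenium and nitrile are needed at all.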